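The source may report more compounds than this note shows. Statements on the series, on what has been measured and on what is new or still open speak of the compounds shown alone.

The shared core appears in three measured compounds: compound 1 `COc1cc(Cc2nc3c(N)nc(F)nc3n2CCOC(C)C)cc(OC)c1OC`, compound 2 `CC#CCCn1c(Cc2cc(OC)c(OC)c(OC)c2)nc2c(N)nc(F)nc21` and compound 3 `CCCn1c(Cc2cc(OC)c(OC)c(OC)c2)nc2c(N)ncnc21`. In a functional assay on MCF7 cells (Homo sapiens) for antiproliferative activity (on this read-out lower numbers stand for stronger inhibition and higher numbers for weaker inhibition), compound 1 gives 15800 nM, compound 2 gives 37200 nM and compound 3 gives 46800 nM. Compound 3 thus has the highest of the three numbers; against compound 2 it sits within the scatter, while against compound 1 it sits beyond it. Among the measured compounds shown here, the one measured step with a single change, a 2.4-fold higher number from compound 1 to compound 2 (0.37 log units; beyond the scatter), concerns the side chain on the ring nitrogen and was modest.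

Compound 4 `CCCn1c(Cc2cc(OC)c(OC)c(OC)c2)nc2c(N)nc(F)nc21` differs from compound 3 by fluoro in place of hydrogen on an aromatic carbon. For the measured compounds named here, no measured step isolates this change: compounds 1 and 2 both carry the fluoro group, but they also carry different side chains, so their lower numbers cannot be assigned to the fluoro group alone. On that basis, little movement beyond the scatter is expected, with at most a slight drift downward; the expected step is a 1.3-fold lower number from compound 3 to compound 4 (0.13 log units; within the scatter). Compound 4 is therefore estimated at 35000 nM, within a range from 15000 nM to 80000 nM.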

Compound 4, half-maximal inhibitory concentration: 25100 nM
Compound 4: middle estimate off by 1.4-fold (0.14 log units), on the high side, within the range that was stated.
By their numbers in this assay, from the lowest: compounds 1, 4, 2 and 3 (each within the scatter of the next, the first and the last beyond it).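

With the side chain on the ring nitrogen held constant, fluoro in place of hydrogen on the aromatic carbon between two ring nitrogen atoms gives a 1.9-fold lower number from compound 3 to compound 4 (0.27 log units; within the scatter) in this assay, so this single change can now be read on its own and stays inside the usual scatter. The side chain of compound 4 also cannot be told apart from the other two, with a 1.5-fold lower number from compound 2 to compound 4 (0.17 log units; within the scatter) and a 1.6-fold higher number from compound 1 to compound 4 (0.20 log units; within the scatter), even though compound 1 and compound 2 differ from each other beyond the scatter. Nothing given here explains these small differences.

Going by these compounds, whether chloro or methoxy on the same aromatic carbon would shift the number more clearly remains open. So does whether fluoro would behave the same way with an isopropoxy-bearing side chain, a longer chain or a terminal amine on the ring nitrogen.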